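Fluoro for Sulfamoyl on an Aziridine Urea

A few compounds are considered here, and "the series" means these few. Any claim that something is new, unique, unknown or untested is made for them only; others in the source may bear on it.

Measured so far:
compound 1, `N#CC1CN1C(=O)Nc1ccc(Cl)c(Cl)c1` — 7200 nM
compound 2, `N#CC1CN1C(=O)Nc1ccc(S(N)(=O)=O)cc1` — > 38000 nM

Compound 1 carries two chloro groups and gives 7200 nM in a functional assay on L1210 cells (Mus musculus) for inhibition, read by MTT assay; on this read-out lower numbers stand for stronger inhibition and higher numbers for weaker inhibition. Compound 2 carries a sulfamoyl group and gives only a limit, > 38000 nM, so no number is known for it. Compound 2 thus sits at the limit of > 38000 nM in this assay, at which 1 of the 2 values shown sits, the weaker end of what has been seen. Among the compounds with values here, no pair of measured compounds differs in a single place, so no measured step is available.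

Compound 3, `N#CC1CN1C(=O)Nc1ccc(F)cc1`, differs from compound 2 by fluoro in place of sulfamoyl on an aromatic carbon. With compound 2 known only as a limit, the size of the step from compound 2 to compound 3 cannot be fixed; a move toward stronger inhibition is expected, and the estimated step of an at least 2.5-fold lower number from compound 2 to compound 3 (0.40 log units; beyond the scatter) reflects that. Compound 3 is expected to give 15000 nM, within 5000 nM to 45000 nM.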

Compound 3, half-maximal inhibitory concentration: 5900 nM
Estimate against measurement, compound 3: 2.5-fold (0.41 log units) above; the range from low to high includes it.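

In this assay, within the data shown here, fluoro in place of sulfamoyl gives the first readable step at this position, an at least 6.4-fold lower number from compound 2 to compound 3 (0.80 log units; beyond the scatter). The change sits on an aromatic carbon para to a group of 8 heavy atoms, so the read-out is shown to depend on which of these two groups occupies that place, with sulfamoyl on the weaker side. The full size of the step stays unknown, since compound 2 stands as a limit and not as a number: the limit of > 38000 nM in this assay, at which 1 of the 3 values shown sits.

The compounds shown leave open how a single chloro, an amine or a carboxylic acid at this place would read in this assay, and so where such groups would fall relative to fluoro and sulfamoyl. Among these compounds, compound 1 differs from compound 3 in more than one place, so it supplies no step to settle this.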